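The compounds below may be only part of what the source reports. "The series", "measured", "known", "first", "only" and "open" are said of these compounds alone.

Measured so far:
- compound 1, `c1ccc(CCc2ccccc2CSc2nccs2)cc1`, 31% in an assay on isolated protein for inhibition of Indoleamine 2,3-dioxygenase 1 (Homo sapiens), with a stated time of 60 min, tested at 10 uM; on this read-out higher numbers stand for more inhibition at the one concentration tested (going by the name of the read-out) and lower numbers for less inhibition
- compound 2, `O=S(=O)(Cc1ccccc1)c1ccccc1CSc1nc2cc(Cl)ccc2[nH]1`, 24% in this assay

The two measured values lie within the usual scatter of each other, so compound 1 cannot be separated from compound 2 on this read-out. Compound 3, `c1ccc(CCc2ccccc2CSC2=NCCS2)cc1`, has not yet been measured. It differs from compound 1 by a group of 5 heavy atoms (3 carbon, 1 nitrogen, 1 sulfur; one five-membered non-aromatic ring with 2 hetero atoms) in place of a group of 5 heavy atoms (3 carbon, 1 nitrogen, 1 sulfur; one five-membered aromatic ring with 2 hetero atoms), on a sulfur. Among the compounds with values here, no step between measured compounds informs this change, so compound 3 is expected to stay close to compound 1, with a step of a number 6 percentage points lower from compound 1 to compound 3 (within the scatter) not expected to exceed the scatter. Compound 3 is estimated at 25%, within a range from 5% to 48%.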

Compound 3, a percentage reported as inhibition, at one concentration (the size of the read-out at that concentration, not a potency): 0%
The estimate for compound 3 lay 25 percentage points above the measured number; the whole stated range lies above it.
By their numbers in this assay, from the lowest: compound 3; then compounds 2 and 1 (each within the scatter of the next).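

On the sulfur whose other neighbour is a saturated chain carbon, putting the five-membered non-aromatic ring in place of 1,3-thiazol-2-yl in this assay gives a number 31 percentage points lower from compound 1 to compound 3 (beyond the scatter). The two groups have the same heavy atoms and the same counts of hydrogen-bond donors and acceptors, so these counts alone do not settle the read-out at this position. Nothing at hand accounts for the size of this step.

The compounds shown leave open how an oxazol-2-yl, an imidazol-2-yl or a pyridin-2-yl group would read at this sulfur. They also leave open what a methylene in place of that sulfur would do.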